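The compounds below may be only part of what the source reports. "The series", "measured", "known", "first", "only" and "open" are said of these compounds alone.

Compound 1 `Cc1ccc(C2CCN(CC(=O)Nc3cccc(C)c3)CC2)cc1` and compound 2 `Cc1cccc(NC(=O)CN2CCC(c3ccccc3)CC2)c1` share a common core and were both examined in a functional assay on cells for agonist activity at D(4) dopamine receptor (Homo sapiens), read by TR-FRET and cAMP accumulation, with a stated time of 30 min; a lower number here means a smaller maximal response, a higher number a larger maximal response. For compound 1 this assay records "not active" (no number reported) and reports no number. Going by the values given here, compound 2 gives 32.9% in this assay, which makes it the only compound here with a number to its name; it stands alone on the numbers, with compound 1 beside it as an entry without a single value. Compound 3 `Cc1cccc(NC(=O)CN2CCC(c3ccc(Cl)cc3)CC2)c1` has not yet been measured. It differs from compound 2 in one place: chloro in place of hydrogen on an aromatic carbon. Among the compounds with values here, no step between measured compounds is available, so there is no measured precedent for the size of this change. The expectation is nonetheless a step downward, likely beyond the usual scatter, because compound 1 in this assay is reported as "not active" (no number reported) while compound 2 reaches a modest maximal response. Compound 3 is therefore expected to show 20% in this assay, with a range from 0% to 42%. This corresponds to an expected step of a number 12.9 percentage points lower from compound 2 to compound 3 (beyond the scatter).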

Compound 3, largest response reached (Emax), in percent of the reference or control that the assay uses: "not active" (no number reported)
Compound 3: no number reported, so the estimate cannot be set against anything.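

Compound 3 carries no number in this assay and compound 1 none either, so no new step can be read from compound 2 to compound 3. The compounds shown leave open how the move from phenyl to 4-chlorophenyl changes the maximal response in numbers. Nothing shown here bears on this result.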